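A few compounds are considered here, and "the series" means these few. Any claim that something is new, unique, unknown or untested is made for them only; others in the source may bear on it.

Compound 1, with the structure `CC1=C(C(=O)Nc2ccc(F)cc2)C(c2ccc([N+](=O)[O-])cc2)N=C(SCc2ccccc2Cl)N1`, and compound 2, with the structure `CC1=C(C(=O)Nc2ccc(F)cc2)C(c2ccc([N+](=O)[O-])cc2)N=C(SCc2cccc(Cl)c2)N1`, share one core and differ only in 3-chlorophenyl in place of 2-chlorophenyl on a saturated chain carbon bound to a sulfur. In a functional assay on the whole organism (artery, strain albino) with Rattus norvegicus as the target, with a stated time of 15 min, at a dose of 10 mg/kg by the oral route (a higher number here means more inhibition at the dose given (going by the name of the read-out), a lower number less inhibition), compound 1 gives 1.5%, while compound 2 gives 2.1%, which amounts to a number 0.6 percentage points higher from compound 1 to compound 2 (within the scatter). Compound 3, with the structure `CC1=C(C(=O)Nc2ccc([N+](=O)[O-])cc2)C(c2ccc(Br)cc2)N=C(SCc2ccccc2Cl)N1`, sits on a different core; how its core differs from that of compound 1 is not broken down here. In this assay compound 3 gives 1.5%. Compound 4, with the structure `CC1=C(C(=O)Nc2ccc([N+](=O)[O-])cc2)C(c2ccc(Br)cc2)N=C(SCc2cccc(Cl)c2)N1`, carries the same change as that seen before, namely (3-chlorophenyl in place of 2-chlorophenyl on a saturated chain carbon bound to a sulfur). The step to compound 4 is expected to be a number 0.5 percentage points higher from compound 3 to compound 4 (within the scatter), small because the same change earlier produced a number 0.6 percentage points higher from compound 1 to compound 2 (within the scatter). Compound 4 is therefore estimated to give 2%. For compound 4 the expected range runs from 0% to 10%.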

Compound 4, a percentage reported as inhibition, in the whole organism at one dose (the size of the read-out at that dose, not a potency): 2.1%
The estimate for compound 4 lay 0.1 percentage points below the measured number; the measured number falls inside the stated range.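

In this assay, 3-chlorophenyl in place of 2-chlorophenyl on a saturated chain carbon bound to a sulfur gives a number 0.6 percentage points higher from compound 3 to compound 4 (within the scatter). Set beside the earlier step, the change reads the same on the two cores: the same change on two cores in this assay, a number 0.6 percentage points higher (within the scatter) from compound 1 to compound 2 and a number 0.6 percentage points higher (within the scatter) from compound 3 to compound 4, 0 percentage points apart, within the scatter of two such steps. Going by these compounds alone, since neither step stands clear of the scatter, this shows only that the swap has no detectable effect on either core, not that a real gain in inhibition carries from one core to the other.

The compounds shown leave open whether a different group on the sulfur, such as a plain longer chain or a chain ending in an amine, would give a step beyond the scatter. On these data alone, whether such a step would then carry across cores also remains open.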